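The compounds below may be only part of what the source reports. "The series", "measured", "known", "first", "only" and "open" are said of these compounds alone.

Working notes on the series. For the measured compounds named here, compound 1 `C=CC(=O)Nc1cc(CCCN(C)C)cc(C)c1Nc1ncc2cc(-c3c(Cl)c(OC)cc(OC)c3Cl)ccc2n1` carries the highest number of the two measured so far: in a functional assay on Huh-7 cells (Homo sapiens) for inhibition, read by sulforhodamine B assay, with a stated time of 72 h (on this read-out higher numbers stand for weaker inhibition and lower numbers for stronger inhibition), compound 1 gives 2240 nM, while compound 2 `C=CC(=O)Nc1cc(SC)ccc1Nc1ncc2cc(-c3c(Cl)c(OC)cc(OC)c3Cl)ccc2n1` gives 936 nM, a gap beyond the scatter. The next member, compound 3 `C=CC(=O)Nc1cc(S(C)(=O)=O)cc(C)c1Nc1ncc2cc(-c3c(Cl)c(OC)cc(OC)c3Cl)ccc2n1`, differs from compound 1 by methylsulfonyl in place of 3-(dimethylamino)propyl on an aromatic carbon. Going by the values given here, no measured pair shows this kind of change, so the direction rests on judgement alone. Compound 3 is expected to stay close to compound 1, with the step of a 1.1-fold higher number from compound 1 to compound 3 (0.05 log units; within the scatter) not clearly beyond the scatter in either direction. The estimate for compound 3 is 2500 nM, within 800 nM to 8000 nM.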

Compound 3, half-maximal inhibitory concentration: 1940 nM
Compound 3: middle estimate off by 1.3-fold (0.11 log units), on the high side; the range from low to high includes it.
By their numbers in this assay, from the lowest: compound 2; then compounds 3 and 1 (each within the scatter of the next).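

In this assay, methylsulfonyl in place of 3-(dimethylamino)propyl on this aromatic carbon gives a 1.2-fold lower number from compound 1 to compound 3 (0.06 log units; within the scatter). This first single-place pair shows that the two groups cannot be told apart at this position, meta to the (vinylcarbonyl)amino group and to the methyl group, even though one is a chain and the other a sulfone. Nothing at hand bears on why the number holds. On these data alone, whether a carboxylic acid, a primary amine or a longer chain on the same carbon would also leave the number in place remains open.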